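Urea series: chloro added to the trifluoromethylphenyl ring

The source may hold more compounds than are shown below. What is called first, only, known or untested is meant among the compounds shown, and "the series" means these compounds.

Measured compounds:
compound 1, `COc1cc(-c2nn(-c3cccc(NC(=O)c4cccc(C(F)(F)F)c4)c3)cc2-c2ccncc2)ccc1Cl`: in a functional assay on RPMI-8226 cells (Homo sapiens) for inhibition, read by sulforhodamine B assay, with a stated time of 48 h (a higher number here means a weaker inhibitor of growth, a lower number a stronger inhibitor of growth), compound 1 gives 26600 nM
compound 2, `COc1cc(-c2nn(-c3cccc(NC(=O)Nc4cccc(C(F)(F)F)c4)c3)cc2-c2ccncc2)ccc1Cl`: in this assay compound 2 gives 3120 nM

Within the data shown here, compound 2 holds the lowest of the two numbers in this assay; its nearest neighbour is compound 1, and the single measured step is an 8.5-fold lower number from compound 1 to compound 2 (0.93 log units; beyond the scatter), a change at the carbonyl carbon, (3-(trifluoromethyl)phenyl)amino in place of 3-(trifluoromethyl)phenyl.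

Compound 3, `COc1cc(-c2nn(-c3cccc(NC(=O)Nc4ccc(Cl)c(C(F)(F)F)c4)c3)cc2-c2ccncc2)ccc1Cl`, differs from compound 2 by chloro in place of hydrogen on an aromatic carbon, ortho to a trifluoromethyl group and para to a large group, so that (3-(trifluoromethyl)phenyl)amino becomes (4-chloro-3-(trifluoromethyl)phenyl)amino. Among the measured compounds shown here, no measured step touches this ring position; the one step in hand concerns the linker and gives no guide to the size or direction of a ring substitution here. The expectation is therefore a small step in this assay, if any, leaning toward a lower number, and it may well sit within the scatter. For compound 3 the estimate in this assay is 1600 nM, with a range of 500 nM to 6000 nM. This estimate means a step of a 2.0-fold lower number from compound 2 to compound 3 (0.29 log units; within the scatter).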

Compound 3, concentration for total growth inhibition: 3250 nM
The estimate for compound 3 lay 2.0-fold (0.31 log units) below the measured number, within the range that was stated.
By their numbers in this assay, from the lowest: compounds 2 and 3 (each within the scatter of the next); then compound 1.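

In this assay, chloro in place of hydrogen on the aromatic carbon ortho to a trifluoromethyl group and para to a large group gives a 1.0-fold higher number from compound 2 to compound 3 (0.02 log units; within the scatter), so the two urea compounds cannot be told apart and this position accepts the chloro with no readable effect on the number. The other new step, an 8.2-fold lower number from compound 1 to compound 3 (0.91 log units; beyond the scatter), closely matches an 8.5-fold lower number from compound 1 to compound 2 (0.93 log units; beyond the scatter), so the separation from the amide compound 1 persists beyond the scatter with or without the chloro, and among these three compounds only the linker is tied to a readable difference. Nothing available bears on the reason for this result.

On these data alone, the finding rests on one substituent at one ring position in the urea series, so it remains open whether a methoxy group, an amine or a carboxylic acid at the same carbon would also leave the number where it stands. As far as these compounds go, it is also open whether the chloro would behave the same way on the amide of compound 1, or whether a longer chain in the linker would hold the step seen for the urea.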